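A Methyl Group Added to Compound 2

This account rests on a few compounds, and the source may have more. Where it says the series, first, only, none or still open, it means among the compounds named here.

Measured in a functional assay on MV4-11 cells (Homo sapiens) for inhibition, read by luminescence, with a stated time of 3 days; on this read-out lower numbers stand for stronger inhibition of growth and higher numbers for weaker inhibition of growth:
compound 1 `CC(C)C1=C(C(=O)N2[C@H](C)CC[C@H]2C(=O)N2CCN(C)CC2)SC2=N[C@@](C)(c3ccc(Cl)cc3)[C@@H](c3ccc(Cl)cc3)N21` gives 190 nM
compound 2 `CC[C@@H]1CC[C@@H](C(=O)N2CCN(C(C)=O)CC2)N1C(=O)C1=C(C(C)C)N2C(=N[C@@](C)(c3ccc(Cl)cc3)[C@H]2c2ccc(Cl)cc2)S1` gives 130 nM
compound 3 `CC(C)C1=C(C(=O)N2[C@H](C)CC[C@H]2C(=O)N2CCN(C)C(C)(C)C2)SC2=N[C@@](C)(c3ccc(Cl)cc3)[C@@H](c3ccc(Cl)cc3)N21` gives 280 nM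

Compound 2, at 130 nM, lies within the scatter of compound 1 and beyond the scatter of compound 3. The next analogue, compound 4 `CC[C@@H]1CC[C@@H](C(=O)N2CCN(C(C)=O)[C@@H](C)C2)N1C(=O)C1=C(C(C)C)N2C(=N[C@@](C)(c3ccc(Cl)cc3)[C@H]2c2ccc(Cl)cc2)S1`, keeps all of compound 2 except for one change: methyl in place of hydrogen on a saturated ring carbon. In words, this is methyl in place of hydrogen on a saturated ring carbon, next to the ring atom that bears an acetyl group.

Among the compounds with values here, no measured pair carries this exact change. Within the data shown here, the one measured step that bears on it is a 1.5-fold higher number from compound 1 to compound 3 (0.17 log units; within the scatter), where a larger group replaces a smaller one on a carbonyl carbon, both holding a six-membered non-aromatic ring with 2 hetero atoms. Neither compound of that pair has an acetyl group, so it is a guide and not a match. On that guide, a step of similar size is expected in this assay, leaning slightly toward a higher number and staying within the scatter. The expected change is a 1.2-fold higher number from compound 2 to compound 4 (0.09 log units; within the scatter). For compound 4 the estimated value is 160 nM, with an expected range from 75 nM to 340 nM.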

Compound 4, concentration for 50% growth inhibition: 120 nM
Estimate against measurement, compound 4: 1.3-fold (0.12 log units) above, within the range that was stated.
By their numbers in this assay, from the lowest: compounds 4, 2, 1 and 3 (each within the scatter of the next, the first and the last beyond it).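

In this assay the step is a 1.1-fold lower number from compound 2 to compound 4 (0.03 log units; within the scatter) and it comes from methyl in place of hydrogen on a saturated ring carbon, next to the ring atom that bears an acetyl group. The earlier step, a 1.5-fold higher number from compound 1 to compound 3 (0.17 log units; within the scatter) in that assay, exchanged one whole group on a carbonyl carbon for another and involved no acetyl group, so it could not isolate this ring carbon; here a single added carbon is the only difference, and the read-out for growth inhibition stays within the scatter, which shows that this position in the acetyl-bearing ring can carry a methyl without a measurable shift. Nothing at hand gives a reason for this result, and no measurement speaks to what the methyl does at the level of the molecule.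

The compounds shown leave open whether the same ring carbon would also carry an ethyl, a hydroxymethyl or a second methyl with the number still within the scatter. They also leave open whether the methyl in its opposite spatial arrangement, or a methyl on a ring carbon of compound 1, would behave as it does in compound 4 .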